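The compounds below may be only part of what the source reports. "The series", "measured", "known", "first", "only" and "open" are said of these compounds alone.

Measured so far in a functional assay on A549 cells (Homo sapiens) for antiproliferative activity, read by MTT assay, with a stated time of 72 h; a lower number here means a stronger inhibitor, a higher number a weaker inhibitor:
compound 1 `FC(F)(F)c1ccc(COc2cccc(Nc3ncnc4cc5c(cc34)OCCOCCOCCOCCO5)c2)cc1`; compound 1 gives 8520 nM.
compound 3 `O=[N+]([O-])c1ccc(COc2cccc(Nc3ncnc4cc5c(cc34)OCCOCCOCCOCCO5)c2)cc1`; compound 3 gives 19800 nM.
compound 2 `FC(F)(F)c1ccc(COc2ccccc2Nc2ncnc3cc4c(cc23)OCCOCCOCCO4)cc1`; for compound 2 the assay reports only a limit, > 100000 nM.

From compound 1 to compound 3 the change is nitro in place of trifluoromethyl on an aromatic carbon, and it gives a 2.3-fold higher number from compound 1 to compound 3 (0.37 log units; beyond the scatter). Compound 2 carries another core; how its core differs from that of compound 1 is not broken down here. Compound 4 `O=[N+]([O-])c1ccc(COc2ccccc2Nc2ncnc3cc4c(cc23)OCCOCCOCCO4)cc1` is not yet measured. It differs from compound 2 by nitro in place of trifluoromethyl on an aromatic carbon, the same change as from compound 1 to compound 3, at the same place. Among the compounds with values here, that measured step is the only guide. The value of compound 2 is a limit (the limit of > 100000 nM in this assay, at which 1 of the 3 values shown sits), so a step of that size from it can only move further past the limit. The step from compound 2 to compound 4 is expected to be a step that the limit leaves unreadable from compound 2 to compound 4 in this assay. In this assay compound 4 is estimated at 200000 nM, from 100000 nM to 500000 nM, most likely reported again as a limit only.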

Compound 4, half-maximal inhibitory concentration: 29900 nM
Beside the measured number, compound 4's estimate is 6.7-fold (0.83 log units) above it, outside the stated range (below it).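

In this assay, nitro in place of trifluoromethyl gives an at least 3.3-fold lower number from compound 2 to compound 4 (0.52 log units; beyond the scatter), opposite in direction to the step on the core of compound 1: the same change on two cores in this assay, a 2.3-fold higher number (0.37 log units; beyond the scatter) from compound 1 to compound 3 and an at least 3.3-fold lower number (0.52 log units; beyond the scatter) from compound 2 to compound 4, at least 7.7-fold (0.89 log units) apart, beyond the scatter of two such steps

From the compounds shown here alone, compound 2 stands at > 100000 nM, which is a limit of the assay, so the full size of this step stays unknown. With one pair on each core, the data show that this change does not carry over unaltered between these two cores, but not which difference between the cores goes with the reversal, nor how a third core would behave.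

Open, going by these compounds, is whether a nitrile at the same place would follow the same split between the cores. On these data alone, an amine or a carboxylic acid there is equally open.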